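The source may report more compounds than this note shows. Statements on the series, on what has been measured and on what is new or still open speak of the compounds shown alone.

Compound 1, `O=C(/C=C/c1cn(-c2ccccc2)nc1-c1ccsc1)c1ccccc1`: in a functional assay on Huh-7 cells (Homo sapiens) for inhibition, read by sulforhodamine B assay, with a stated time of 72 h (on this read-out higher numbers stand for weaker inhibition and lower numbers for stronger inhibition), compound 1 gives 4700 nM.
Compound 2, `O=C(/C=C/c1cn(-c2ccccc2)nc1-c1cccnc1)c1cc[nH]c1`: in this assay compound 2 gives 3300 nM.
Compound 3, `O=C(/C=C/c1cn(-c2ccccc2)nc1-c1cccnc1)c1c[nH]c2ccccc12`: in this assay compound 3 gives 3200 nM.

Compound 3 has the lowest of the three numbers, but its nearest neighbour compound 2 sits within the scatter, and compound 1 also sits within the scatter of it, so no ordering among the three can be claimed. Among the measured compounds shown here, the one step available at the carbonyl carbon, a 1.0-fold lower number from compound 2 to compound 3 (0.01 log units; within the scatter), stays within the scatter: exchanging the ketone aryl group has left the read-out unchanged so far.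

Compound 4, `O=C(/C=C/c1cn(-c2ccccc2)nc1-c1cccnc1)c1ccccc1`, keeps the shared core of compound 3 and changes only the ketone side: phenyl in place of 1H-indol-3-yl on a carbonyl carbon. The same phenyl ketone is present in compound 1, which differs from compound 4 elsewhere, and compound 1 gives a number in the same range as compounds 2 and 3. Both pieces of evidence point to no change beyond the scatter; if anything, the number may drift slightly upward toward compound 1. For compound 4 the expected step is therefore a 1.3-fold higher number from compound 3 to compound 4 (0.10 log units; within the scatter). Compound 4 is estimated at 4000 nM in this assay, within a range of 2000 nM to 9000 nM.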

Compound 4, half-maximal inhibitory concentration: 2300 nM
Estimate against measurement, compound 4: 1.7-fold (0.24 log units) above, and the stated range covers the measured number.
By their numbers in this assay, from the lowest: compounds 4, 3, 2 and 1 (each within the scatter of the next, the first and the last beyond it).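

At the carbonyl carbon, with pyridin-3-yl held constant on the shared core, phenyl in place of 1H-indol-3-yl gives a 1.4-fold lower number from compound 3 to compound 4 (0.14 log units; within the scatter) in this assay, and phenyl in place of 1H-pyrrol-3-yl gives a 1.4-fold lower number from compound 2 to compound 4 (0.16 log units; within the scatter), so the three ketone groups cannot be told apart, and the read-out stays within the scatter even without the hydrogen-bond donor counted on 1H-indol-3-yl. Among the compounds shown here, the only step here beyond the scatter lies at the other changed place, where pyridin-3-yl in place of thiophen-3-yl on an aromatic carbon gives a 2.0-fold lower number from compound 1 to compound 4 (0.31 log units; beyond the scatter), a modest step resting on a single pair with the phenyl ketone. No data offered here explain either result.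

From the compounds shown here alone, whether the difference between pyridin-3-yl and thiophen-3-yl carries over to the 1H-pyrrol-3-yl or 1H-indol-3-yl ketones remains open. Going by these compounds, it is also open whether a larger change at the carbonyl carbon, such as a saturated alkyl chain or a phenyl carrying an amine or a carboxylic acid, would move the number beyond the scatter.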